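The source may hold more compounds than are shown below. What is called first, only, known or untested is meant among the compounds shown, and "the series" means these compounds.

Measured so far in a physicochemical assay for lipophilicity, measured as octanol-water partition, at pH 7.4; a lower number here means a more polar compound, a higher number a more lipophilic compound:
compound 1, `Fc1ccccc1Cc1nc(-c2nc(C(F)(F)F)n[nH]2)n2ccccc12`, gives 3.8;
compound 2, `Cc1ncc(Cc2nc(-c3nc(C(F)(F)F)n[nH]3)n3ccccc23)cn1`, gives 2.1;
compound 3, `Fc1ncncc1Cn1nc(-c2nc(C(F)(F)F)n[nH]2)c2cccnc21`, gives 3.2.

Compound 1 stands highest of the three: compound 3 comes nearest, and compound 2 lies furthest away, with both gaps beyond the scatter. Within the data shown here, the one single-point step among them, a number 1.70 log units lower from compound 1 to compound 2 (beyond the scatter), swaps one aryl group for another on the saturated chain carbon and leaves the trifluoromethyl untouched.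

Compound 4, `CS(=O)(=O)c1n[nH]c(-c2nc(Cc3ccccc3F)c3ccccn23)n1`, keeps everything in compound 1 except that change: methylsulfonyl in place of trifluoromethyl on an aromatic carbon. Among the measured compounds shown here, no measured pair here alters that position, so nothing in this set speaks directly to how this assay will answer. What can be said is that a group with no hydrogen-bond acceptors leaves and one with two acceptors enters, so a sizeable drop is expected, a number 1.80 log units lower from compound 1 to compound 4 (beyond the scatter), and compound 4 is estimated at 2, within 1.2 to 2.8.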

Compound 4, distribution coefficient: 1.2
Estimate against measurement, compound 4: 0.80 log units above, and the stated range covers the measured number.
By their numbers in this assay, from the lowest: compound 4; then compound 2; then compound 3; then compound 1.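

The position on the five-membered aromatic ring with 3 nitrogen, between two ring nitrogen atoms, proves highly sensitive in this assay: methylsulfonyl in place of trifluoromethyl gives a number 2.60 log units lower from compound 1 to compound 4 (beyond the scatter), with the rest of the molecule unchanged. The earlier compounds shown here showed a large step only from a swap of aryl groups on the saturated chain carbon, so this result adds a second place where a single change moves the number strongly. Nothing measured here explains why this exchange has so large an effect.

A nitrile or a primary amide on the same aromatic carbon would show how other groups read here. On these data alone, it also remains open whether methylsulfonyl would bring a step of similar size with the 2-methylpyrimidin-5-yl group of compound 2 in place.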